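This account rests on a few compounds, and the source may have more. Where it says the series, first, only, none or still open, it means among the compounds named here.

Compound 1 `O=C1O[C@H]([C@@H](O)Cn2cc(-c3cccc(O)c3)nn2)C(OCc2ccccc2)=C1OCc1ccccc1` gives 39000 nM in an ADME assay on HFF cells (Homo sapiens) for cytotoxicity, read by MTT assay, with a stated time of 72 h; a lower number here means a stronger inhibitor, a higher number a weaker inhibitor.
Compound 2 `Cc1ccc(-c2cn(C[C@H](O)[C@H]3OC(=O)C(OCc4ccccc4)=C3OCc3ccccc3)nn2)cc1` reaches only the limit of this assay, > 100000 nM.
Compound 3 `O=C1O[C@H]([C@@H](O)Cn2ccnn2)C(OCc2ccccc2)=C1OCc1ccccc1` gives 610 nM in this assay.

Among the two plain numbers, compound 1 stands as the higher one, so it is the weaker inhibitor of cell growth; the nearest number is that of compound 3, which lies a long way lower. Compound 4 `O=C1O[C@H]([C@@H](O)Cn2cc(CCO)nn2)C(OCc2ccccc2)=C1OCc1ccccc1` has not yet been measured. It differs from compound 1 in one place: 2-hydroxyethyl in place of 3-hydroxyphenyl on an aromatic carbon.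

Among the compounds with values here, two measured steps bear on this change. Removing the whole 3-hydroxyphenyl group gave a 64-fold lower number from compound 1 to compound 3 (1.81 log units; beyond the scatter), and from compound 2 the same removal gave an at least 160-fold lower number from compound 2 to compound 3 (2.21 log units; beyond the scatter). Swapping one aromatic group for another gave an at least 2.5-fold higher number from compound 1 to compound 2 (0.40 log units; beyond the scatter). The 2-hydroxyethyl group is far smaller than the 3-hydroxyphenyl group but is not hydrogen, so a step downward, smaller than the step to compound 3, is expected. The estimate for compound 4 in this assay is therefore 10000 nM, with a range from 2000 nM to 50000 nM, which is expected to mean a 3.9-fold lower number from compound 1 to compound 4 (0.59 log units; beyond the scatter).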

Compound 4, half-maximal inhibitory concentration: 58500 nM
Beside the measured number, compound 4's estimate is 5.9-fold (0.77 log units) below it; the measured number lies above the stated range.
By their numbers in this assay, from the lowest: compound 3; then compounds 1 and 4 (each within the scatter of the next). At a limit, above all of these: compound 2.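

In this assay, putting the 2-hydroxyethyl chain on this aromatic carbon of the triazole in place of the 3-hydroxyphenyl group gave a 1.5-fold higher number from compound 1 to compound 4 (0.18 log units; within the scatter), so the two compounds cannot be told apart here and an aromatic ring is not needed there to keep the number high. Set against hydrogen, the same chain gave a 96-fold higher number from compound 3 to compound 4 (1.98 log units; beyond the scatter), a jump that the earlier compounds had shown only for groups bearing a six-membered aromatic ring. Compound 2 stands at a limit of this assay: the limit of > 100000 nM in this assay, at which 1 of the 4 values shown sits. Putting the 2-hydroxyethyl chain in place of the 4-methylphenyl group gave an at least 1.7-fold lower number from compound 2 to compound 4 (0.23 log units; that floor lies within the scatter), so this step settles nothing.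

The compounds shown leave open how small a group at this carbon can be and still bring the large rise over hydrogen, as a single methyl might test. They also leave open whether the chain's hydroxyl matters, which a plain ethyl chain or a 2-aminoethyl chain would address.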